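Moving a hydroxyl on a pyridine-like core against topoisomerase 1

The compounds below may be only part of what the source reports. "The series", "measured", "known", "first", "only" and "open" are said of these compounds alone.

Measured compounds:
compound 1 `Oc1ccc(-c2cc(-c3cccs3)cc(-c3ccccc3O)n2)cc1` 72.2%
compound 2 `Oc1ccc(-c2cc(-c3cccs3)cc(-c3cccc(O)c3)n2)cc1` 85.7%
compound 3 `Oc1cccc(-c2cc(-c3ccoc3)cc(-c3ccccc3O)n2)c1` 29.5%

All three were tested in an assay on isolated protein for inhibition of DNA topoisomerase 1 (Homo sapiens), with a stated time of 30 min, tested at 100 uM; on this read-out lower numbers stand for a weaker effect and higher numbers for a stronger effect at the one concentration tested. Compound 1 and compound 2 share a core and differ in one place (3-hydroxyphenyl in place of 2-hydroxyphenyl on an aromatic carbon), a change that made the step of a number 13.5 percentage points higher from compound 1 to compound 2 (beyond the scatter). Compound 4 `Oc1cccc(-c2cc(-c3ccoc3)cc(-c3cccc(O)c3)n2)c1` has not yet been measured; it arises from compound 3 by 3-hydroxyphenyl in place of 2-hydroxyphenyl on an aromatic carbon. This is the same kind of change, but the surroundings differ: in compound 1 the place is meta to a 4-hydroxyphenyl group and a thiophen-2-yl group, whereas in compound 3 it is meta to a 3-hydroxyphenyl group and a furan-3-yl group. The difference between the two cores is not broken down here. Compound 3 stands lowest of the three measured compounds. Within the data shown here, a step of similar size is expected for compound 4, namely a number 13.5 percentage points higher from compound 3 to compound 4 (beyond the scatter), since the only measured example is the step from compound 1 to compound 2; with the different core, the expectation is held loosely. Compound 4 is estimated at 43%, within 25% to 62%.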

Compound 4, a percentage reported as inhibition, at one concentration (the size of the read-out at that concentration, not a potency): 44.2%
Estimate against measurement, compound 4: 1.2 percentage points below; the range from low to high includes it.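

Putting 3-hydroxyphenyl in place of 2-hydroxyphenyl on the core of compound 3 gave a number 14.7 percentage points higher from compound 3 to compound 4 (beyond the scatter). Set beside the earlier case, the two steps agree: the same change on two cores in this assay, a number 13.5 percentage points higher (beyond the scatter) from compound 1 to compound 2 and a number 14.7 percentage points higher (beyond the scatter) from compound 3 to compound 4, 1.2 percentage points apart, within the scatter of two such steps. So in this assay the change carried over between these two cores, but this rests on only two pairs and does not show that it would give a similar step on any other core, or why the two hydroxyphenyl groups differ.

The two cores differ in more than one place, so the share of the thiophen-2-yl and furan-3-yl groups stays unresolved. Also open, as far as these compounds go, is what an amine or a carboxylic acid would do in place of the hydroxyl on this ring.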